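Chloro to Iodo on the Shared Core

The source may hold more compounds than are shown below. What is called first, only, known or untested is meant among the compounds shown, and "the series" means these compounds.

In a functional assay on MCF7 cells (Homo sapiens) for antiproliferative activity (on this read-out higher numbers stand for weaker inhibition and lower numbers for stronger inhibition), compound 2 `Clc1ncnc2c1ncn2C1COc2ccccc2CO1` gives 1250 nM, level with compound 1 `FC(F)(F)c1ncnc2c1ncn2C1COc2ccccc2CO1`, which in this assay gives 1250 nM. For the measured compounds named here, the only measured step, no change at the digits printed from compound 1 to compound 2 (within the scatter), shows that exchanging one substituent for another at this aromatic carbon did not move the read-out. Compound 3 `Ic1ncnc2c1ncn2C1COc2ccccc2CO1` differs from compound 2 by iodo in place of chloro on an aromatic carbon. Because no change at the digits printed from compound 1 to compound 2 (within the scatter) stayed within the scatter, the expected step is no change at the digits printed from compound 2 to compound 3 (within the scatter), nothing beyond the scatter in either direction. Compound 3 is therefore estimated at 1250 nM in this assay, within a range from 500 nM to 3000 nM.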

Compound 3, half-maximal inhibitory concentration: 1250 nM
Compound 3: middle estimate and measured number agree at the digits printed; the range from low to high includes it.
By their numbers in this assay, from the lowest: compounds 1, 2 and 3 (each within the scatter of the next).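

In this assay iodo in place of chloro gives no change at the digits printed from compound 2 to compound 3 (within the scatter) and iodo in place of trifluoromethyl gives no change at the digits printed from compound 1 to compound 3 (within the scatter) on this aromatic carbon. For the compounds shown here, three different groups at this one place now give the same read-out, where the earlier compounds offered only two. Nothing available explains why the read-out stays level here. Still open, as far as these compounds go, is whether an amine, a carboxylic acid or a longer chain on this carbon would move the read-out beyond the scatter.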